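Thiazolyloxy to trifluoromethoxy on a biaryl dihydrobenzopyran acid

This account rests on a few compounds, and the source may have more. Where it says the series, first, only, none or still open, it means among the compounds named here.

Compound 1 `O=C(O)CC[C@H]1CCc2cc(-c3cc(OC(F)(F)F)ccc3F)ccc2O1` has been measured in a functional assay on HEK293 cells for agonist activity at Free fatty acid receptor 1 (Homo sapiens), read by HTRF and inositol phosphate accumulation, with a stated time of 60 min (on this read-out lower numbers stand for an effect already at smaller amounts and higher numbers for an effect only at larger amounts of compound), and gives 2100 nM. Compound 2 `COc1cc(Oc2ncc(C)s2)cc(-c2ccc3c(c2)CC[C@H](CCC(=O)O)O3)c1F` is reported in this assay only as a limit of the assay, > 10000 nM, which is the limit of > 10000 nM in this assay, at which 1 of the 2 values shown sits. Compound 3 `COc1cc(OC(F)(F)F)cc(-c2ccc3c(c2)CC[C@H](CCC(=O)O)O3)c1F` has not yet been measured; it differs from compound 2 by trifluoromethyl in place of 5-methyl-1,3-thiazol-2-yl on an oxygen on an aromatic ring, read one bond further out as (5-methyl-1,3-thiazol-2-yl)oxy to trifluoromethoxy. Since compound 3 carries the trifluoromethoxy also present in compound 1 at 2100 nM, compound 3 is expected to shift well beyond the scatter toward smaller amounts, an estimated step of an at least 6.6-fold lower number from compound 2 to compound 3 (0.82 log units; beyond the scatter). Compound 3 is expected at 1500 nM, in a range from 400 nM to 6000 nM.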

Compound 3, half-maximal effective concentration: 4400 nM
For compound 3 the middle estimate is 2.9-fold (0.47 log units) below the measured one; low and high end bracket the measured number.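

In this assay, for the compounds shown here, the change from (5-methyl-1,3-thiazol-2-yl)oxy to trifluoromethoxy gives an at least 2.2-fold lower number from compound 2 to compound 3 (0.35 log units; beyond the scatter), the first measurable value with the methoxy present. On these data alone, the true size of this step stays unknown because compound 2 is reported only as a limit: the limit of > 10000 nM in this assay, at which 1 of the 3 values shown sits. Going by these compounds alone, with trifluoromethoxy held fixed, methoxy in place of hydrogen on an aromatic carbon gives a 2.1-fold higher number from compound 1 to compound 3 (0.32 log units; beyond the scatter), so the added methoxy brings no gain in this pair. As far as these compounds go, it remains open how a nitrile or an amine in place of trifluoromethoxy would read in this assay.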